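A methyl step from compound 1 to compound 4

A few compounds are considered here, and "the series" means these few. Any claim that something is new, unique, unknown or untested is made for them only; others in the source may bear on it.

In a functional assay on HEY cells (Homo sapiens) for cytotoxicity, read by MTT assay, with a stated time of 72 h (a lower number here means a stronger inhibitor, a higher number a weaker inhibitor), compound 1 (`N[C@H]1CC[C@H](Nc2c(C(=O)NCc3ccc(F)cc3)nc(Br)c3cccnc23)CC1`) stands at "not determined" (no result reported) and so offers no number to start from. Two relatives do have numbers. Compound 2 (`N[C@H]1CC[C@H](NC(=O)c2nc(Br)c3cccnc3c2NCc2ccc(F)cc2)CC1`) gives 7100 nM in this assay and compound 3 (`N[C@H]1CC[C@H](Nc2c(C(=O)NCc3ccc(Cl)cc3Cl)nc(Br)c3cccnc23)CC1`) gives 5000 nM in the same test. These two values lie within the usual scatter of each other.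

Compound 4 (`C[C@H](NC(=O)c1nc(Br)c2cccnc2c1N[C@H]1CC[C@H](N)CC1)c1ccc(F)cc1`) differs from compound 1 by methyl in place of hydrogen on a saturated chain carbon bound to an amide-type nitrogen and an aromatic carbon and reads as methyl in place of hydrogen on a saturated chain carbon bound to an amide-type nitrogen and an aromatic carbon, or 4-fluorobenzyl to 1-(4-fluorophenyl)ethyl. Among the measured compounds shown here, no measured pair shows what such a change does, so the data give no direct guide to its size. In this assay the expected step is none beyond the scatter, with no preferred direction, and the expectation leans on compound 3 at 5000 nM as a reference. The estimate for compound 4 is 5000 nM with an expected range from 2000 nM to 13000 nM.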

Compound 4, half-maximal inhibitory concentration: > 10000 nM
Compound 4: a limit, no number (the forecaster's own chance of this, stated with the estimate: 15%); at least 2.0-fold (0.30 log units) between middle value and limit.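

Compound 4 yields only a limit of the assay and not a number, so 1-(4-fluorophenyl)ethyl gives no readable potency here: the limit of > 10000 nM in this assay, at which 1 of the 4 values shown sits.

Among the compounds shown here, on the amide-type nitrogen, 1-(4-fluorophenyl)ethyl in place of 2,4-dichlorobenzyl gives an at least 2.0-fold higher number from compound 3 to compound 4 (0.30 log units; that floor lies within the scatter), so this pair shows no firm loss in this assay, only that the change brings no gain into the measurable range. On these data alone, the step from compound 1 cannot be read, as compound 1 has no value, and the size of the effect of methyl in place of hydrogen on this saturated chain carbon remains unknown.

The compounds shown leave open how an ethyl or a hydroxymethyl group on this carbon would read in this assay. They also leave open the opposite configuration of the methyl-bearing carbon.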